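This account rests on a few compounds, and the source may have more. Where it says the series, first, only, none or still open, it means among the compounds named here.

Measured so far:
compound 1 `C/C(=N\OCC(=O)O)c1ccccc1` — < 20%
compound 2 `C/C(=N\OCC(=O)O)c1cccc(Cl)c1` — 20%
compound 3 `C/C(=N\OCC(=O)O)c1ccc(N(C)C)cc1` — < 20%

In a functional assay on the whole organism for inhibition, with Rattus norvegicus as the target, read by paw edema, with stated times of 1 h and 3 h, at a dose of 50 mg/kg by the oral route (a higher number here means more inhibition at the dose given (going by the name of the read-out), a lower number less inhibition), compound 1 gives < 20%, a limit of the assay rather than a number. Compound 3 likewise gives < 20%, a limit. Compound 2 gives 20% and is the only number shown. The values of compound 1 and compound 3 are limits (the limit of < 20% in this assay, at which 2 of the 3 values shown sit). The step of a number no lower from compound 1 to compound 2 (the limit leaves the size open) is a number no lower, its size not readable; the step that the two limits leave unreadable from compound 1 to compound 3 is unreadable between two limits. Compound 4 `C/C(=N\OCC(=O)O)c1ccc(C2CCCCC2)c(Cl)c1` differs from compound 2 by cyclohexyl in place of hydrogen on an aromatic carbon. No measured step involves a cyclohexyl group, so nothing shown bears directly on this change. The step of a number 5 percentage points higher from compound 2 to compound 4 (within the scatter) is therefore expected to stay within the usual scatter. Compound 4 is expected to give 25%, between 10% and 45%.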

Compound 4, a percentage reported as inhibition, in the whole organism at one dose (the size of the read-out at that dose, not a potency): < 20%
Compound 4: no number, only a limit (the forecaster's own chance of this, stated with the estimate: 40%); middle value at least 5 percentage points away from the limit.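

With the chloro group of compound 2 kept, cyclohexyl on the aromatic carbon ortho to it gives, in this assay, a number no higher from compound 2 to compound 4 (the limit leaves the size open). Compound 4 gives < 20%, a limit of the assay and not a number. At this position, cyclohexyl therefore brings no readable gain over compound 2, and the series stays largely at the floor of the assay: the limit of < 20% in this assay, at which 3 of the 4 values shown sit.

How far compound 4 lies under compound 2 cannot be read. Open, going by these compounds, is whether a methoxy group, an amine or a carboxylic acid in the same place, with the chloro group kept, would give a value above the limit.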